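The source may report more compounds than this note shows. Statements on the series, on what has been measured and on what is new or still open speak of the compounds shown alone.

Compound 1 `C[C@@H](NC1CCN(CCCc2c[nH]c3ccc(-n4cnnc4)cc23)CC1)c1ccccc1`: 13 nM
Compound 2 `OC[C@H](NC1CCN(CCCc2c[nH]c3ccc(-n4cncn4)cc23)CC1)c1ccccc1`: 7.4 nM

In an assay on CHO cells for agonist activity at 5-hydroxytryptamine receptor 1D (Homo sapiens), read by GTPgammaS binding (on this read-out higher numbers stand for an effect only at larger amounts of compound and lower numbers for an effect already at smaller amounts), compound 1 gives 13 nM, and compound 2 gives 7.4 nM. The gap between these two numbers lies within the usual scatter of repeated measurements, so compound 1 cannot be set apart from compound 2 on this read-out.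

Compound 3 `CC(CO)(NC1CCN(CCCc2c[nH]c3ccc(-n4cnnc4)cc23)CC1)c1ccccc1` has not yet been measured. It differs from compound 1 in one place: 1-(hydroxymethyl)-1-phenylethyl in place of 1-phenylethyl on an amine nitrogen. Among the compounds with values here, no measured pair shows this exact change, so its effect has to be guessed.

Compound 2 carries a hydroxymethyl group at a comparable position and behaves much like compound 1, which suggests the hydroxymethyl alone does little. Adding a further carbon on the same atom is expected to shift the number somewhat upward for compound 3, giving a step of a 1.9-fold higher number from compound 1 to compound 3 (0.28 log units; within the scatter), possibly no larger than the scatter. Compound 3 is therefore estimated at 25 nM, with a range from 8 nM to 80 nM.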

Compound 3, half-maximal effective concentration: 3.4 nM
For compound 3 the middle estimate is 7.4-fold (0.87 log units) above the measured one; measured number below the stated range.
By their numbers in this assay, from the lowest: compound 3; then compounds 2 and 1 (each within the scatter of the next).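

On an amine nitrogen, the larger 1-(hydroxymethyl)-1-phenylethyl group is more than tolerated: in this assay, putting it in place of 1-phenylethyl gives a 3.8-fold lower number from compound 1 to compound 3 (0.58 log units; beyond the scatter), so less compound is needed for the same effect. Within the data shown here, this is the first comparison here that differs in one place and gives a clear answer, as compound 1 and compound 2 differ in more than one place and their numbers lie within the scatter. Nothing measured here explains the drop.

Still open, from the compounds shown here alone, is whether the oxygen of the new group matters, or simply the extra carbon on that atom; an ethyl, methoxymethyl or aminomethyl group at the same place would separate the two. Going by these compounds, whether a longer chain, such as hydroxyethyl, is accepted there also remains unknown.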